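The compounds below may be only part of what the source reports. "The series", "measured", "known", "first", "only" and "open" are said of these compounds alone.

Compound 2 `Nc1scc(CN2CCN(c3cccc(F)c3F)CC2)c1C(=O)c1ccc(Cl)cc1` gives 0% in an assay on CHO cells for displacement of a labelled ligand from adenosine receptor A3 (Homo sapiens), read by scintillation counting, with a stated time of 120 min, tested at 10 uM (on this read-out higher numbers stand for more inhibition at the one concentration tested (going by the name of the read-out) and lower numbers for less inhibition), and compound 1 `Nc1scc(CN2CCN(c3cccc(Cl)c3Cl)CC2)c1C(=O)c1ccc(Cl)cc1` gives 0%. Going by the values given here, the one measured step, no change at the digits printed from compound 1 to compound 2 (within the scatter), shows that swapping the halogens on the aryl group attached to the ring nitrogen leaves the read-out unchanged. Among the compounds with values here, compound 2 thus stands level with compound 1, and the series so far shows no signal at the test concentration.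

Compound 3 `Nc1scc(CN2CCN(CCCc3ccc(Cl)cc3)CC2)c1C(=O)c1ccc(Cl)cc1` differs from compound 2 by 3-(4-chlorophenyl)propyl in place of 2,3-difluorophenyl on an amine nitrogen in a ring. Within the data shown here, no measured step swaps an aryl group on that nitrogen for an arylalkyl chain, so the one known step is only a weak guide; it argues that changes at this position have so far produced no movement. On that basis the step of a number 5 percentage points higher from compound 2 to compound 3 (within the scatter) is expected to stay within the scatter, though the wider range reflects the absence of any comparable measured change. Compound 3 is therefore estimated at 5%, with a range from -10% to 35%.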

Compound 3, a percentage reported as inhibition, at one concentration (the size of the read-out at that concentration, not a potency): 0%
Compound 3: the middle estimate sits 5 percentage points above what was measured, and the stated range covers the measured number.
By their numbers in this assay, from the lowest: compounds 1, 2 and 3 (each within the scatter of the next).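

In this assay, replacing 2,3-difluorophenyl with 3-(4-chlorophenyl)propyl on the amine nitrogen gives no change at the digits printed from compound 2 to compound 3 (within the scatter), and replacing 2,3-dichlorophenyl with the same group gives no change at the digits printed from compound 1 to compound 3 (within the scatter). The earlier step covered only a change of halogens on a directly attached phenyl group, whereas these steps extend the flat result to a propyl chain ending in a 4-chlorophenyl group, so the three groups at this position do not separate at the one concentration tested. No measurement on hand accounts for this result.

Still open, going by these compounds, is whether a group of another kind on this nitrogen, such as a carboxylic acid, a basic amine or a longer chain, would move the read-out. The compounds shown also leave open whether a replacement for the 4-chlorophenyl group on the carbonyl would do so.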